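The compounds below may be only part of what the source reports. "The series", "measured", "known", "first", "only" and "open" are said of these compounds alone.

Two hydroxamic acids have so far been measured in a functional assay on ACHN cells (Homo sapiens) for antiproliferative activity; on this read-out lower numbers stand for stronger inhibition of growth and higher numbers for weaker inhibition of growth. Compound 1 `COc1ccc(CN2CC=C(CCC(=O)NO)C2=O)cc1` gives 2480 nM in this assay, and compound 2 `O=C(CCC1=CCN(Cc2cccc(C(F)(F)F)c2)C1=O)NO` gives 670 nM; compound 2 thus shows the lower of the two numbers, a gap beyond the usual scatter. Compound 3 `O=C(CCC1=CCN(Cc2ccccc2)C1=O)NO` differs from compound 2 by hydrogen in place of trifluoromethyl on an aromatic carbon, on an aromatic carbon of a six-membered aromatic ring of carbon only, meta to a large group. Going by the values given here, no measured pair shows this change, so removing the group is expected to weaken growth inhibition modestly, a step of a 2.2-fold higher number from compound 2 to compound 3 (0.35 log units; beyond the scatter). Compound 3 is therefore estimated at 1500 nM, within 600 nM to 4000 nM.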

Compound 3, concentration for 50% growth inhibition: 1080 nM
Compound 3: the middle estimate sits 1.4-fold (0.14 log units) above what was measured; the range from low to high includes it.
By their numbers in this assay, from the lowest: compounds 2 and 3 (each within the scatter of the next); then compound 1.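

In this assay, putting hydrogen in place of trifluoromethyl gives a 1.6-fold higher number from compound 2 to compound 3 (0.21 log units; within the scatter), so at this position the two cannot be told apart. Putting hydrogen in place of methoxy on an aromatic carbon gives a 2.3-fold lower number from compound 1 to compound 3 (0.36 log units; beyond the scatter), so of these two groups only methoxy separates from hydrogen. Nothing measured here accounts for either step.

From the compounds shown here alone, whether chlorine or an amine on the aromatic ring would separate from hydrogen remains open. So does the effect of a longer chain carrying the hydroxamic acid.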